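Cytotoxicity of three measured compounds and one untested partner

The source may report more compounds than this note shows. Statements on the series, on what has been measured and on what is new or still open speak of the compounds shown alone.

Compound 1, `N#Cc1ccc(S(=O)(=O)N2C/C(=C\c3cccnc3)C(=O)/C(=C/c3ccccc3F)C2)cc1`: > 20000 nM
Compound 2, `CC(=O)Nc1ccc(S(=O)(=O)N2C/C(=C\c3cccnc3)C(=O)/C(=C/c3ccccc3F)C2)cc1`: 15600 nM
Compound 3, `N#Cc1ccc(S(=O)(=O)N2C/C(=C\c3cccnc3)C(=O)/C(=C/c3ccccc3C(F)(F)F)C2)cc1`: 13200 nM

In an ADME assay on L02 cells (Homo sapiens) for cytotoxicity, read by MTT assay, with a stated time of 24 h (on this read-out higher numbers stand for weaker inhibition and lower numbers for stronger inhibition), compound 1 gives only a limit of the assay, > 20000 nM, as the limit of > 20000 nM in this assay, at which 1 of the 3 values shown sits, records. In this assay compound 2 gives 15600 nM, and compound 3 gives 13200 nM. The change from compound 1 to compound 2 is acetamido in place of cyano on an aromatic carbon, and it made an at least 1.2-fold lower number from compound 1 to compound 2 (0.10 log units; that floor lies within the scatter). The two cores differ by trifluoromethyl in place of fluoro on an aromatic carbon, which gave an at least 1.5-fold lower number from compound 1 to compound 3 (0.18 log units; that floor lies within the scatter).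

Compound 4, `CC(=O)Nc1ccc(S(=O)(=O)N2C/C(=C\c3cccnc3)C(=O)/C(=C/c3ccccc3C(F)(F)F)C2)cc1`, has not yet been measured in this assay. It differs from compound 3 by acetamido in place of cyano on an aromatic carbon, the same change that separates compound 1 from compound 2, at the same place. Because the earlier step, an at least 1.2-fold lower number from compound 1 to compound 2 (0.10 log units; that floor lies within the scatter), starts from a limit and its floor lies within the scatter, compound 4 is expected to sit close to compound 3, with an expected step of a 1.3-fold lower number from compound 3 to compound 4 (0.12 log units; within the scatter). For compound 4 the estimated value in this assay is 10000 nM, expected to fall between 4000 nM and 25000 nM.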

Compound 4, half-maximal inhibitory concentration: 15300 nM
Estimate against measurement, compound 4: 1.5-fold (0.18 log units) below, and the stated range covers the measured number.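

In this assay, the acetamido in place of cyano change on the core of compound 3 gave a 1.2-fold higher number from compound 3 to compound 4 (0.06 log units; within the scatter), and the trifluoromethyl in place of fluoro change on the core of compound 2 gave a 1.0-fold lower number from compound 2 to compound 4 (0.01 log units; within the scatter). Whether the acetamido change acts alike on the two cores stays unsettled: the same change on two cores in this assay, an at least 1.2-fold lower number (0.10 log units; that floor lies within the scatter) from compound 1 to compound 2 and a 1.2-fold higher number (0.06 log units; within the scatter) from compound 3 to compound 4; the limit leaves it open whether they differ. The trifluoromethyl change stands the same way: the same change on two cores in this assay, an at least 1.5-fold lower number (0.18 log units; that floor lies within the scatter) from compound 1 to compound 3 and a 1.0-fold lower number (0.01 log units; within the scatter) from compound 2 to compound 4; the limit leaves it open whether they differ.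

The compounds shown leave open how a carboxylic acid or an amine would read in this assay in place of cyano or acetamido on the same aromatic carbon. They also leave open whether a methoxy group in place of fluoro or trifluoromethyl would move the number by more than the scatter.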